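The source may report more compounds than this note shows. Statements on the series, on what has been measured and on what is new or still open speak of the compounds shown alone.

Compound 3 `C/C(=C\CC/C(C)=C/CC[C@@H]1[C@@]2(C)CCC(=O)C(C)(C)[C@H]2CC[C@@]1(C)O)CC/C=C(\C)C(=O)OCc1cn(-c2ccc(C(C)(C)C)cc2)nn1` sits at a limit of a functional assay on DU-145 cells (Homo sapiens) for antiproliferative activity, read by MTT assay, with a stated time of 48 h; a lower number here means a stronger inhibitor, a higher number a weaker inhibitor: compound 3 gives > 150000 nM, a limit of the assay and not a number. Compound 1 `C/C(=C\CC/C(C)=C/CC[C@@H]1[C@@]2(C)CCC(=O)C(C)(C)[C@H]2CC[C@@]1(C)O)CC/C=C(\C)C(=O)OCc1cn(-c2ccccc2)nn1` gives 95500 nM in this assay. Compound 2 `C/C(=C\CC/C(C)=C/CC[C@@H]1[C@@]2(C)CCC(=O)C(C)(C)[C@H]2CC[C@@]1(C)O)CC/C=C(\C)C(=O)OCc1cn(-c2ccc(F)c(Cl)c2)nn1` likewise reaches a limit, giving > 150000 nM. Compound 4 `C/C(=C\CC/C(C)=C/CC[C@@H]1[C@@]2(C)CCC(=O)C(C)(C)[C@H]2CC[C@@]1(C)O)CC/C=C(\C)C(=O)OCc1cn(-c2ccccc2F)nn1` differs from compound 3 in one place: 2-fluorophenyl in place of 4-(tert-butyl)phenyl on an aromatic nitrogen. Among the measured compounds shown here, the steps that bear on it are an at least 1.5-fold higher number from compound 1 to compound 3 (0.19 log units; that floor lies within the scatter) and an at least 1.5-fold higher number from compound 1 to compound 2 (0.19 log units; that floor lies within the scatter); owing to the limit of > 150000 nM in this assay, at which 2 of the 3 values shown sit, only their floors are readable. Compound 4 carries a smaller ring substituent and stands nearer to compound 1, whose 95500 nM is a number. A modest fall in the number is therefore expected, an at least 1.2-fold lower number from compound 3 to compound 4 (0.09 log units; that floor lies within the scatter). Compound 4 is estimated at 120000 nM, between 60000 nM and 250000 nM.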

Compound 4, half-maximal inhibitory concentration: > 150000 nM
Compound 4: only a limit was reported; the forecaster's own chance of this, stated with the estimate: 45%; middle value at least 1.2-fold (0.09 log units) from the limit.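

In this assay the value of compound 4 is a limit of the assay and not a number. A lone fluoro in place of hydrogen on the phenyl ring gives an at least 1.5-fold higher number from compound 1 to compound 4 (0.19 log units; that floor lies within the scatter), so 2-fluorophenyl, with fewer heavy atoms than 4-(tert-butyl)phenyl, reaches that same limit, leaving compound 1 the only one of the four with a number. The steps among compounds 2, 3 and 4 cannot be read because both ends of each sit at a limit: the limit of > 150000 nM in this assay, at which 3 of the 4 values shown sit.

On these data alone, how far compounds 2, 3 and 4 lie past that limit stays open. Also open, as far as these compounds go, is whether an amine or a carboxylic acid on the phenyl ring would give a readable number.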